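This account rests on a few compounds, and the source may have more. Where it says the series, first, only, none or still open, it means among the compounds named here.

Compound 3 `CCCCc1ccc(-c2cc(C)cc(C(=O)Nc3nn[nH]n3)n2)cc1` gives 67% in a functional assay on the whole organism with Rattus norvegicus as the target, at a dose of 3 mg/kg by the oral route (a higher number here means a stronger effect of the compound at the dose given, a lower number a weaker effect), the second highest of the three numbers shown. Compound 1 `CCOc1cc(C(=O)Nc2nn[nH]n2)nc(-c2ccc(N)cc2)c1` gives 62% in this assay, within the scatter of compound 3, while compound 2 `Nc1ccc(-c2cccc(C(=O)Nc3nn[nH]n3)n2)cc1` gives 81% in this assay, beyond the scatter above it. Among the measured compounds shown here, the only single-site step measured so far, a number 19 percentage points higher from compound 1 to compound 2 (beyond the scatter), concerns a different position and does not involve the butyl or amino groups.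

Compound 4 `Cc1cc(C(=O)Nc2nn[nH]n2)nc(-c2ccc(N)cc2)c1` differs from compound 3 by amino in place of butyl on an aromatic carbon. For the measured compounds named here, no measured pair shows this exchange, so the expectation rests on the two compounds that carry the amino group: compound 1 gives 62% in this assay, and compound 2 gives 81%. Compound 4 is therefore expected to land near those values, with a step of a number 3 percentage points higher from compound 3 to compound 4 (within the scatter) from compound 3, within the scatter. The estimated value for compound 4 in this assay is 70%, with a likely range from 55% to 85%.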

Compound 4, a percentage reported as inhibition, in the whole organism at one dose (the size of the read-out at that dose, not a potency): 100%
Compound 4: the middle estimate sits 30 percentage points below what was measured, and the stated range ends below it.
By their numbers in this assay, from the lowest: compounds 1 and 3 (each within the scatter of the next); then compound 2; then compound 4.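

In this assay, amino in place of butyl on the aromatic carbon brings a large rise (a number 33 percentage points higher from compound 3 to compound 4 (beyond the scatter)), the first measured view of this exchange, in which a chain of four carbons gives way to a single nitrogen. At the other site that varies, methyl outperforms both other groups seen there, whether it replaces hydrogen (a number 19 percentage points higher from compound 2 to compound 4 (beyond the scatter)) or ethoxy (a number 38 percentage points higher from compound 1 to compound 4 (beyond the scatter)), so this site responds strongly to small changes with amino in place. Nothing measured here explains why either change raises the number.

Still open, going by these compounds, is whether a group such as ethyl or chlorine at the methyl site would match methyl. On these data alone, it is equally open whether a hydroxyl or a dimethylamino group could stand in for amino.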